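The source may hold more compounds than are shown below. What is called first, only, known or untested is meant among the compounds shown, and "the series" means these compounds.

Two compounds of the series have been run in an ADME assay on HEL cells (Homo sapiens) for cytotoxicity, with a stated time of 3 days; on this read-out higher numbers stand for lower toxicity in this test and lower numbers for higher toxicity in this test: compound 1 `Cc1cc(-c2ccc(O)cc2)c2ncc(CSCCc3ccccc3)n2c1` and compound 2 `Cc1cc(-c2ccc(O)cc2)cn2c(CSCCc3ccccc3)cnc12`. In this assay compound 1 gives 13.7 ug/mL. For compound 2 this assay reports only a limit, > 50 ug/mL. Compound 2 therefore stands at the limit of > 50 ug/mL in this assay, at which 1 of the 2 values shown sits, without a number of its own. Compound 3 `Cc1cc(I)cn2c(CSCCc3ccccc3)cnc12` differs from compound 2 by iodo in place of 4-hydroxyphenyl on an aromatic carbon. Going by the values given here, no measured step accompanies this change, so no shift beyond the scatter is expected, and the read-out may again be a limit. Compound 3 is expected to give 40 ug/mL in this assay, between 15 ug/mL and 100 ug/mL. The estimated step of an at least 1.2-fold lower number from compound 2 to compound 3 (0.09 log units; that floor lies within the scatter) is accordingly small.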

Compound 3, half-maximal cytotoxic concentration: > 50 ug/mL
Compound 3 was reported as a limit; the forecaster's own chance of this, stated with the estimate: 50%; middle value at least 1.2-fold (0.09 log units) away from the limit.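

Compound 2 and compound 3 are both reported only as limits in this assay, so no step between them can be read: the limit of > 50 ug/mL in this assay, at which 2 of the 3 values shown sit.

On these data alone, how far either compound lies beyond that limit, and so what iodo in place of 4-hydroxyphenyl does to the read-out, stays open.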